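This account rests on a few compounds, and the source may have more. Where it says the series, first, only, none or still open, it means among the compounds named here.

Measured in a physicochemical assay for lipophilicity, using the shake flask method, in phosphate buffer, measured as octanol-water partition, with a stated time of 2 h, at pH 7.4, tested at 1 uM; on this read-out lower numbers stand for lower lipophilicity and higher numbers for higher lipophilicity:
- compound 1 `O=[N+]([O-])c1ccc2c(ccn2-c2ccc(O[C@H]3O[C@H](CO)[C@@H](O)[C@H](O)[C@@H]3O)c(F)c2)c1`: 1.9
- compound 2 `CS(=O)(=O)Nc1ccc2c(ccn2-c2ccc(O[C@H]3O[C@H](CO)[C@@H](O)[C@H](O)[C@@H]3O)c(Cl)c2)c1`: 1.8
- compound 3 `OC[C@H]1O[C@H](Oc2ccc(N3CCc4ccccc43)cc2)[C@@H](O)[C@@H](O)[C@@H]1O`: 2.3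

Compound 3, at 2.3, holds the highest of the three numbers. The gaps down to compound 1, at 1.9, and to compound 2, at 1.8, both lie beyond the scatter.

The next compound to be measured is compound 4 `OC[C@H]1O[C@H](Oc2ccc(N3CCc4ccccc43)cc2Cl)[C@@H](O)[C@@H](O)[C@@H]1O`. It departs from compound 3 in one place: chloro in place of hydrogen on an aromatic carbon. This is chloro in place of hydrogen on an aromatic carbon, ortho to a large group and meta to a 2,3-dihydro-1H-indol-1-yl group.

Going by the values given here, no two measured compounds differ in a single place, so the series offers no direct calibration for this step and the expectation rests on judgement. In this assay the estimated step is upward and moderate, beyond the scatter: a number 0.50 log units higher from compound 3 to compound 4 (beyond the scatter). For compound 4 the estimated value is 2.8, with an expected range of 2.4 to 3.2.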

Compound 4, distribution coefficient: 2.8
Estimate against measurement, compound 4: no gap at the digits printed; the range from low to high includes it.
By their numbers in this assay, from the lowest: compounds 2 and 1 (each within the scatter of the next); then compound 3; then compound 4.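

In this assay, chloro in place of hydrogen on an aromatic carbon, ortho to a large group and meta to a 2,3-dihydro-1H-indol-1-yl group, gives a number 0.50 log units higher from compound 3 to compound 4 (beyond the scatter). This is the only single-place step among the compounds shown, so it gives the series its first direct reading at this position. The read-out responds to this one chlorine atom, though no data shown give a reason for the size of the step.

On these data alone, whether a similar step would follow from a different group at this position, such as methoxy, a nitrile or an amine, remains open. Going by these compounds alone, also open is whether chloro in place of hydrogen would give a similar step on the core of compound 1, which has no matched pair here.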